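Replacing the (dimethylamino)methyl group of compound 3

The source may hold more compounds than are shown below. What is called first, only, known or untested is meant among the compounds shown, and "the series" means these compounds.

Of the compounds shown here, three with a shared core have been measured so far. In an ADME assay on microsomes from liver (Homo sapiens) for metabolic stability, read by LC-MS, using NADPH, with stated times of 5 min and 30 min, tested at 1 uM (a lower number here means slower removal, a higher number faster removal of the compound), compound 1 (`Cn1cc(-c2cnc(NCc3c(F)ccc4c3CCO4)c3cn[nH]c(=O)c23)cn1`) gives 21 mL.min-1.g-1 and compound 2 (`CN(C)C(=O)c1cc(-c2cnc(NCc3c(F)ccc4c3CCO4)c3cn[nH]c(=O)c23)n(C)n1`) gives 21 mL.min-1.g-1 under the same conditions. Compound 3 (`Cc1nc(CN(C)C)ccc1-c1cnc(NCc2c(F)ccc3c2CCO3)c2cn[nH]c(=O)c12`) gives 13 mL.min-1.g-1 and stands within the scatter of both others, so these numbers do not separate the three.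

Compound 4 (`CNC(=O)c1ccc(-c2cnc(NCc3c(F)ccc4c3CCO4)c3cn[nH]c(=O)c23)c(C)n1`) has not been measured. It differs from compound 3 by one swap, methylcarbamoyl in place of (dimethylamino)methyl on an aromatic carbon, next to the ring nitrogen.

Among the compounds with values here, no measured step makes this exact swap, so the evidence is indirect. Compound 2 already carries a dimethylcarbamoyl group, on a different ring, and the comparison with compound 3 shows a 1.6-fold lower number from compound 2 to compound 3 (0.21 log units; within the scatter) as a small move. The other two steps are just as modest, with a 1.6-fold lower number from compound 1 to compound 3 (0.21 log units; within the scatter) and no change at the digits printed from compound 1 to compound 2 (within the scatter) as their sizes. Within the data shown here, every change of group tried so far has stayed inside the scatter, although only three compounds support that observation.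

The step expected in this assay is therefore slight (a 1.3-fold higher number from compound 3 to compound 4 (0.12 log units; within the scatter)) and nothing beyond the scatter. Compound 4 is estimated at 17 mL.min-1.g-1 with an expected range from 9 mL.min-1.g-1 to 32 mL.min-1.g-1 (an estimate only).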

Compound 4, intrinsic clearance in microsomes: 23 mL.min-1.g-1
Beside the measured number, compound 4's estimate is 1.4-fold (0.13 log units) below it; the range from low to high includes it.
By their numbers in this assay, from the lowest: compounds 3, 1, 2 and 4 (each within the scatter of the next).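

In this assay, within the data shown here, this is the first direct test of the position para to a large group and next to the ring nitrogen, and methylcarbamoyl in place of (dimethylamino)methyl stays inside the usual scatter (a 1.8-fold higher number from compound 3 to compound 4 (0.25 log units; within the scatter)). The swap exchanges an amine side chain for an amide of the same heavy-atom count, and this position tolerates that exchange without a clear shift in the clearance number. The whole 2-methyl-6-(methylcarbamoyl)pyridin-3-yl group also stays within the scatter against both pyrazole-bearing compounds (a 1.1-fold higher number from compound 2 to compound 4 (0.04 log units; within the scatter); a 1.1-fold higher number from compound 1 to compound 4 (0.04 log units; within the scatter)), so the four compounds remain unseparated, and nothing shown here bears on why these steps are so small.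

Still open, as far as these compounds go, is whether any other group at this position, such as a carboxylic acid, a primary amide or an amide with a longer chain on its nitrogen, would move the number beyond the scatter. The compounds shown also leave open what the methyl group on the same ring contributes, since every pyridine here carries it, and whether a hydrogen or an ethyl group there would read any differently.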